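Cyclopropyl for butyl on the alkyne of compound 1

The compounds below may be only part of what the source reports. "The series", "measured", "known", "first", "only" and "open" are said of these compounds alone.

This account follows a single step in an ADME assay on MRC5 cells (Homo sapiens) for cytotoxicity, read by MTT assay (a higher number here means that more compound is tolerated, a lower number that less compound is tolerated), from a measured nucleoside to an unmeasured one. Among the compounds with values here, compound 1 `CCCCC#Cc1cn([C@@H]2O[C@H](CO)[C@@H](O)[C@H]2O)c(=O)[nH]c1=O` is the least tolerated of the three compounds measured so far: in this assay compound 1 gives 11600 nM. The closest neighbour in this assay is compound 3 `O=c1[nH]cc(C#CC(O)c2ccccc2)c(=O)[nH]1`, which gives 38400 nM, a gap beyond the usual scatter; the furthest is compound 2 `CCCCCCC#Cc1c[nH]c(=O)[nH]c1=O`, which gives 94900 nM, also beyond the scatter. Within the data shown here, neither compound 2 nor compound 3 differs from compound 1 in only one place, so no single-change step is available to guide the next estimate.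

Compound 4 `O=c1[nH]c(=O)n([C@@H]2O[C@H](CO)[C@@H](O)[C@H]2O)cc1C#CC1CC1` shares the core of compound 1 and differs from it in one place: cyclopropyl in place of butyl on a triple-bonded carbon. Nothing in the measured set shows how this assay responds to such a change. Compound 4 is therefore expected to give 15000 nM, with a range from 6000 nM to 40000 nM, a step of a 1.3-fold higher number from compound 1 to compound 4 (0.11 log units; within the scatter) that is estimated to lie within the scatter, tilted if at all toward slightly more compound being tolerated.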

Compound 4, half-maximal cytotoxic concentration: 24200 nM
Compound 4: middle estimate off by 1.6-fold (0.21 log units), on the low side; low and high end bracket the measured number.
By their numbers in this assay, from the lowest: compound 1; then compounds 4 and 3 (each within the scatter of the next); then compound 2.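

In this assay, within the data shown here, this is the first single-place step available at this triple-bonded carbon: cyclopropyl in place of butyl gives a 2.1-fold higher number from compound 1 to compound 4 (0.32 log units; beyond the scatter), a modest move toward more compound being tolerated. Among these compounds, it shows that, with the core of compound 1 held constant, changing only this group is enough to shift the number beyond the scatter. Nothing at hand explains why the step runs in this direction.

One step cannot show whether the same exchange would have a similar effect on the core of compound 2, which carries no sugar. Also open, on these data alone, is how a longer chain, an amine or a carboxylic acid at this triple-bonded carbon would compare on the core of compound 1.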